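The compounds below may be only part of what the source reports. "The series", "measured", "known", "first", "only" and "open" are said of these compounds alone.

Compound 1 `CN(C(=O)NC(=O)c1ccc(Cl)cc1Cl)c1nc(C(F)(F)F)c(C(=O)N/N=C/c2cccc(C(F)(F)F)c2)s1` gives 9.6 ug/mL in a functional assay on HeLa cells (Homo sapiens) for inhibition, read by MTT assay, with a stated time of 72 h; a higher number here means a weaker inhibitor, a lower number a stronger inhibitor.
Compound 2 `CN(C(=O)NC(=O)c1ccc(C(F)(F)F)cc1)c1nc(C(F)(F)F)c(C(=O)N/N=C/c2cccc(C(F)(F)F)c2)s1` gives 6.2 ug/mL in this assay.

Compound 2 has the lower of the two numbers, yet the step of a 1.5-fold lower number from compound 1 to compound 2 (0.19 log units; within the scatter) lies within the scatter, so neither compound is set apart from the other. Compound 3 `CN(C(=O)NC(=O)c1ccc(F)c(F)c1)c1nc(C(F)(F)F)c(C(=O)N/N=C/c2cccc(C(F)(F)F)c2)s1` differs from compound 2 by 3,4-difluorophenyl in place of 4-(trifluoromethyl)phenyl on a carbonyl carbon. Among the compounds with values here, the only measured step at that carbonyl carbon, a 1.5-fold lower number from compound 1 to compound 2 (0.19 log units; within the scatter), was within the scatter, so a further change of the aryl group there is expected to stay within the scatter as well, with no direction to predict. Compound 3 is therefore expected to give 7 ug/mL in this assay, in the range 3.5 ug/mL to 14 ug/mL, which is the step of a 1.1-fold higher number from compound 2 to compound 3 (0.05 log units; within the scatter) expected from compound 2.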

Compound 3, half-maximal inhibitory concentration: 4.21 ug/mL
The estimate for compound 3 lay 1.7-fold (0.22 log units) above the measured number, within the range that was stated.
By their numbers in this assay, from the lowest: compounds 3, 2 and 1 (each within the scatter of the next, the first and the last beyond it).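

In this assay the aryl group on the carbonyl carbon now shows a step beyond the scatter, though a modest one: a 2.3-fold lower number from compound 1 to compound 3 (0.36 log units; beyond the scatter) with 3,4-difluorophenyl in place of 2,4-dichlorophenyl. The step of a 1.5-fold lower number from compound 2 to compound 3 (0.17 log units; within the scatter) stays within the scatter, so 3,4-difluorophenyl and 4-(trifluoromethyl)phenyl are not told apart here. No available evidence bears on either step.

Going by these compounds, it remains open whether an aryl group carrying an amine or a carboxylic acid would fit on this carbonyl carbon, and how a longer alkyl chain there would compare.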